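Replacing the 2-nitrophenyl sulfonyl group of compound 2

The source may report more compounds than this note shows. Statements on the series, on what has been measured and on what is new or still open speak of the compounds shown alone.

Measured so far in a functional assay on HL-60 cells (Homo sapiens) for inhibition, read by CCK-8 assay, with a stated time of 48 h, tested at 20 uM; a lower number here means less inhibition of growth, a higher number more inhibition of growth at the concentration tested
compound 1 `Cc1ccc(S(=O)(=O)Oc2ccccc2/C=C(\C#N)C(=O)Nc2nnc(Cc3cccc(F)c3)s2)cc1` gives 11%
compound 2 `N#C/C(=C\c1ccccc1OS(=O)(=O)c1ccccc1[N+](=O)[O-])C(=O)Nc1nnc(Cc2cccc(F)c2)s1` gives 23%

Compound 2 stands highest of the two measured compounds (23%), with compound 1 giving 11%. The gap between the two lies beyond the scatter. The next structure, compound 3 `N#C/C(=C\c1ccccc1OS(=O)(=O)c1ccc(F)cc1)C(=O)Nc1nnc(Cc2cccc(F)c2)s1`, follows from 4-fluorophenyl in place of 2-nitrophenyl on a sulfonyl sulfur. Among the measured compounds shown here, one measured step bears on this change, a modest one on that same sulfonyl sulfur, namely a number 12 percentage points higher from compound 1 to compound 2 (beyond the scatter) (2-nitrophenyl in place of 4-methylphenyl). How 4-fluorophenyl compares with 4-methylphenyl has not been measured, so a modest fall is expected, smaller than or similar to that step. In this assay the expected change is a number 8 percentage points lower from compound 2 to compound 3 (within the scatter) (an estimate). Compound 3 is estimated at 15% (expected range 5% to 28%).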

Compound 3, percent growth inhibition at one concentration: 22%
Compound 3: middle estimate off by 7 percentage points, on the low side; low and high end bracket the measured number.
By their numbers in this assay, from the lowest: compound 1; then compounds 3 and 2 (each within the scatter of the next).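

In this assay 4-fluorophenyl in place of 2-nitrophenyl on the sulfonyl sulfur gives a number 1 percentage points lower from compound 2 to compound 3 (within the scatter) and so shows that this position tolerates the loss of the nitro group without a change beyond the scatter. Fluoro in place of methyl on an aromatic carbon gives a number 11 percentage points higher from compound 1 to compound 3 (beyond the scatter) and thereby sets compound 1 apart from both compound 2 and compound 3. Nothing available explains these differences.

Still open, as far as these compounds go, is how a plain methyl or a dimethylamino group on the sulfonyl sulfur, in place of the aromatic ring, would fare. Whether any group at this position can raise inhibition beyond that of compound 2 and compound 3 also remains unanswered.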